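Swapping the aryl group on a triazole nitrogen

The source may hold more compounds than are shown below. What is called first, only, known or untested is meant among the compounds shown, and "the series" means these compounds.

Three compounds share one core: an aromatic five-membered ring bearing three nitrogens, linked through an ether to a fused bicyclic fragment, with an aryl group on one ring nitrogen. Compound 1 is `CCc1ccc(-n2cc(COc3ccc4c(c3)CCC4)nn2)cc1`. Compound 2 is `Cc1cc(C)c(-n2cc(COc3ccc4c(c3)CCC4)nn2)c(C)c1`. Compound 3 is `Cc1cccc(-n2cc(COc3ccc4c(c3)CCC4)nn2)c1`.

The read-out is an ADME assay on HEK293 cells (Homo sapiens) for inhibition, read by MTT assay, with a stated time of 48 h, tested at 25 uM; on this read-out lower numbers stand for less inhibition and higher numbers for more inhibition at the one concentration tested (going by the name of the read-out). Compound 1 stands without a number here, as no result was reported for it: "not determined" (no result reported). Compound 2 was measured, and in this assay compound 2 gives 16.6%, a small response at the single concentration tested.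

Compound 3 differs from compound 1 in one place: 3-methylphenyl in place of 4-ethylphenyl on an aromatic nitrogen. Among the compounds with values here, no step between two measured compounds is available to calibrate this change, so the size of the step in this assay cannot be read from data; the expectation is none beyond the usual scatter, as both aryl groups are plain carbon rings with no donors or acceptors.

The value for compound 3 in this assay is therefore estimated at 15%, within 0% to 35%. That number is expected to be level with the inhibition compound 2 gives, 16.6%.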

Compound 3, a percentage reported as inhibition, at one concentration (the size of the read-out at that concentration, not a potency): 23.4%
Estimate against measurement, compound 3: 8.4 percentage points below; the measured number falls inside the stated range.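

No step can be read between compound 1 and compound 3 in this assay: only compound 3 carries a number, 23.4%. The compounds shown leave open how much changing the aryl group on the ring nitrogen shifts this inhibition. No supporting evidence bears on this result.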